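A few compounds are considered here, and "the series" means these few. Any claim that something is new, unique, unknown or untested is made for them only; others in the source may bear on it.

For the measured compounds named here, compound 3 `CCOC(=O)c1cnc(N2CCN(Cc3ccc(C(N)=O)cc3)CC2)nc1Oc1c(C)cc(-c2ccc(C#N)cc2)cc1C` is the only compound of the three measured that gives an actual number in an ADME assay on MT4 cells (Homo sapiens) for cytotoxicity, read by MTT assay, with a stated time of 4 days (a lower number here means that less compound is tolerated, a higher number that more compound is tolerated), namely 66500 nM. Compound 1 `CCOC(=O)c1cnc(N2CCN(Cc3cccc(C#N)c3)CC2)nc1Oc1c(C)cc(-c2ccc(C#N)cc2)cc1C` reaches only a limit of this assay, > 125000 nM. Compound 2 `CCOC(=O)c1cnc(N2CCN(Cc3ccccc3Br)CC2)nc1Oc1c(C)cc(-c2ccc(C#N)cc2)cc1C` likewise stops at the limit > 125000 nM. The steps toward compound 3 read an at least 1.8-fold lower number from compound 1 to compound 3 (0.27 log units; that floor lies within the scatter) and an at least 1.8-fold lower number from compound 2 to compound 3 (0.27 log units; that floor lies within the scatter), while a step that the two limits leave unreadable from compound 1 to compound 2.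

Compound 4 `CCOC(=O)c1cnc(N2CCN(Cc3cccc(OC)c3)CC2)nc1Oc1c(C)cc(-c2ccc(C#N)cc2)cc1C` carries the change (3-methoxyphenyl in place of 4-carbamoylphenyl on a saturated chain carbon bound to an amine nitrogen in a ring). The two readable steps both run toward the 4-carbamoylphenyl group and are no larger than the scatter allows; reversing that group, as here, is therefore expected to give no step beyond the scatter in this assay, at most a drift back toward the limit, with a 1.4-fold higher number from compound 3 to compound 4 (0.15 log units; within the scatter) as the expected step. Compound 4 is thus estimated at 95000 nM, within 40000 nM to 125000 nM.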

Compound 4, half-maximal cytotoxic concentration: > 125000 nM
Compound 4 ended at the assay's limit; the forecaster's own chance of this, stated with the estimate: 50%; middle value at least 1.3-fold (0.11 log units) away from the limit.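

In this assay, for the compounds shown here, 3-methoxyphenyl joins 3-cyanophenyl and 2-bromophenyl at the limit on this saturated chain carbon, leaving 4-carbamoylphenyl as the only group with an actual number: the limit of > 125000 nM in this assay, at which 3 of the 4 values shown sit. The change from 4-carbamoylphenyl to 3-methoxyphenyl gives an at least 1.8-fold higher number from compound 3 to compound 4 (0.27 log units; that floor lies within the scatter), so this third limit-bound group still does not separate compound 3 from the others beyond the scatter, though the true gap may be larger. The steps among compound 1, compound 2 and compound 4 cannot be read.

As far as these compounds go, it remains open how an amine or a carboxylic acid in place of the carbamoyl group would read in this assay.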